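A few compounds are considered here, and "the series" means these few. Any claim that something is new, unique, unknown or untested is made for them only; others in the source may bear on it.

Measured so far in a physicochemical assay for solubility, measured as kinetic solubility; on this read-out lower numbers stand for lower solubility and higher numbers for higher solubility:

- compound 1, `CCC/N=C1\S/C(=C\c2ccc(O)c(Cl)c2)C(=O)N1c1ccccc1C`: 79000 nM
- compound 2, `CCC/N=C1\S/C(=C\c2ccc(O)c(C)c2)C(=O)N1c1ccccc1C`: 78000 nM
- compound 3, `CCC/N=C1\S/C(=C\c2ccc(O)c(C#N)c2)C(=O)N1c1ccccc1C`: 220000 nM

Compound 3 gives the highest solubility of the three. Its step from compound 1 is a 2.8-fold higher number from compound 1 to compound 3 (0.44 log units; beyond the scatter), and its step from compound 2 is a 2.8-fold higher number from compound 2 to compound 3 (0.45 log units; beyond the scatter); both are modest but beyond the scatter, while compounds 1 and 2 sit within the scatter of each other, shown by a 1.0-fold lower number from compound 1 to compound 2 (0.01 log units; within the scatter).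

Compound 4, `CCC/N=C1\S/C(=C\c2ccc(O)c(C(F)(F)F)c2)C(=O)N1c1ccccc1C`, has not yet been measured. It differs from compound 3 in one place: trifluoromethyl in place of cyano on an aromatic carbon.

The two steps that bear on this change are the ones leading into compound 3, in which a cyano group replaced a chloro or a methyl group and raised solubility by a modest amount in each case. Compound 4 gives up the cyano group, and with it the single hydrogen-bond acceptor counted for that group, in favour of a trifluoromethyl group that carries no acceptor. The expectation is therefore that the gain seen in compound 3 is lost again and that solubility falls back toward the level of compounds 1 and 2, a modest step downward expected as a 3.1-fold lower number from compound 3 to compound 4 (0.50 log units; beyond the scatter). For compound 4 the expected value in this assay is 70000 nM, with a likely range from 30000 nM to 160000 nM.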

Compound 4, solubility: 14000 nM
Compound 4: the middle estimate sits 5.0-fold (0.70 log units) above what was measured, and the stated range ends above it.
By their numbers in this assay, from the lowest: compound 4; then compounds 2 and 1 (each within the scatter of the next); then compound 3.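

For the compounds shown here, measured in this assay, the change from cyano to trifluoromethyl on this aromatic carbon, ortho to the hydroxy group, gives a 16-fold lower number from compound 3 to compound 4 (1.20 log units; beyond the scatter), the largest step in this set, so this one position can move the read-out much further than the earlier compounds showed. The earlier compounds shown here showed only cyano standing apart from chloro and methyl, which sit within the scatter of each other, but trifluoromethyl does not simply return to their level, as it falls beyond the scatter with a 5.6-fold lower number from compound 2 to compound 4 (0.75 log units; beyond the scatter) and with a 5.6-fold lower number from compound 1 to compound 4 (0.75 log units; beyond the scatter), making the order at this position a three-level one: cyano highest, chloro and methyl together, trifluoromethyl lowest. No measurement available here accounts for why trifluoromethyl lies so far under the other three groups.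

The compounds shown leave open where a methoxy group, an amine or a carboxylic acid on this same aromatic carbon would fall in that order. They also leave open whether the same order of cyano, chloro, methyl and trifluoromethyl would hold on the shared core with the hydroxy group removed.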